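From Bromo to Hydroxy: A Swap Without Direct Precedent

The compounds below may be only part of what the source reports. "The series", "measured", "known", "first", "only" and "open" are said of these compounds alone.

Of the compounds shown here, three have been measured so far in a functional assay on HCT-116 cells (Homo sapiens) for inhibition, read by MTT assay, with a stated time of 48 h; on this read-out higher numbers stand for weaker inhibition and lower numbers for stronger inhibition. Compound 1 `C/C=C/C=C/C(=O)N(Cc1ccc(OC)c(O)c1)c1cc(OC)c(OC)c(OC)c1` gives 180 nM, compound 2 `COc1ccc(CN(C(=O)CO)c2cc(OC)c(OC)c(OC)c2)cc1O` gives 520 nM, and compound 3 `C/C=C/C(=O)N(Cc1ccc(OC)c(Br)c1)c1cc(OC)c(OC)c(OC)c1` gives 2800 nM. Compound 3 therefore has the highest number of the three, which makes it the weakest inhibitor so far.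

Compound 4 `C/C=C/C(=O)N(Cc1ccc(OC)c(O)c1)c1cc(OC)c(OC)c(OC)c1` differs from compound 3 in one place: hydroxy in place of bromo on an aromatic carbon. This puts hydroxy in place of bromo on an aromatic carbon, turning 3-bromo-4-methoxyphenyl into 3-hydroxy-4-methoxyphenyl. Among the compounds with values here, no measured pair makes this exact swap, so the evidence is indirect.

Compounds 1 and 2 both carry the 3-hydroxy-4-methoxyphenyl group and differ only on the carbonyl carbon. That change, hydroxymethyl in place of penta-1,3-dien-1-yl, is a modest step, a 2.9-fold higher number from compound 1 to compound 2 (0.46 log units; beyond the scatter). Both sit well under compound 3, but they also differ from it on the carbonyl carbon, so those gaps cannot be credited to the bromo and hydroxy groups alone. Compound 4 keeps the carbonyl side of compound 3, which adds uncertainty.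

A clear drop beyond the scatter is still expected, with an estimated change an 8.0-fold lower number from compound 3 to compound 4 (0.90 log units; beyond the scatter). For compound 4, the expected value in this assay is 350 nM, with an estimated range of 120 nM to 1000 nM.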

Compound 4, half-maximal inhibitory concentration: 55 nM
The estimate for compound 4 lay 6.4-fold (0.80 log units) above the measured number; measured number outside the range, below it.
By their numbers in this assay, from the lowest: compound 4; then compound 1; then compound 2; then compound 3.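

Seen directly, with everything else in the molecule held fixed, the change from 3-bromo-4-methoxyphenyl to 3-hydroxy-4-methoxyphenyl is a large one in this assay (a 51-fold lower number from compound 3 to compound 4 (1.71 log units; beyond the scatter)), so this single aromatic position can by itself shift the number strongly. The carbonyl side also counts once the hydroxy group is in place: among the three compounds with 3-hydroxy-4-methoxyphenyl, the prop-1-en-1-yl chain gives the lowest number, ahead of the hydroxymethyl group (a 9.5-fold lower number from compound 2 to compound 4 (0.98 log units; beyond the scatter)) and of the longer penta-1,3-dien-1-yl chain (a 3.3-fold lower number from compound 1 to compound 4 (0.51 log units; beyond the scatter)), which makes compound 4 the strongest inhibitor of the four. No measurement here offers a reason for the size of the bromo-to-hydroxy step.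

Bromo and hydroxy are compared on only one carbonyl side, so it remains open whether the same swap would give a step of similar size with the hydroxymethyl group or the penta-1,3-dien-1-yl chain. On these data alone, it is also open how an amine or a fluoro group at this aromatic position would compare with hydroxy.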